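The source may report more compounds than this note shows. Statements on the series, on what has been measured and on what is new or still open speak of the compounds shown alone.

Three compounds that share one core and differ only in the aryl group on the amine have been measured. Compound 1 `Fc1cccc(-c2nc(Nc3ccccc3)c3cc(F)ccc3n2)c1` gives 47800 nM in a functional assay on MDA-MB-231 cells (Homo sapiens) for cytotoxicity, read by MTT assay, with a stated time of 48 h; a lower number here means a stronger inhibitor, a higher number a weaker inhibitor. Compound 2 `COc1ccc(Nc2nc(-c3cccc(F)c3)nc3ccc(F)cc23)cc1`, with methoxy in place of hydrogen on an aromatic carbon, gives 47300 nM in this assay, and the change a 1.0-fold lower number from compound 1 to compound 2 (0.00 log units; within the scatter) lies within the scatter. For compound 3 `Fc1cccc(-c2nc(Nc3ccc(Cl)cc3)c3cc(F)ccc3n2)c1` the this assay reports > 50000 nM, which is a limit of the assay and not a number. Compound 3 therefore stands at the limit of > 50000 nM in this assay, at which 1 of the 3 values shown sits. The steps of an at least 1.0-fold higher number from compound 1 to compound 3 (0.01 log units; that floor lies within the scatter) and an at least 1.0-fold higher number from compound 2 to compound 3 (0.02 log units; that floor lies within the scatter) both have a floor that lies within the scatter, so on the numbers shown compound 3 is not separated from compound 1 or compound 2.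

Compound 4 `Nc1cccc(Nc2nc(-c3cccc(F)c3)nc3ccc(F)cc23)c1` differs from compound 3 in one place: 3-aminophenyl in place of 4-chlorophenyl on a nitrogen on an aromatic ring. Among the compounds with values here, no measured step introduces an amino group on that ring; the steps that bear on the change are those on the same ring, methoxy and chloro in place of hydrogen, and all three of them sit within the scatter. The expectation is accordingly for no step beyond the scatter, an at least 1.0-fold lower number from compound 3 to compound 4 (0.01 log units; that floor lies within the scatter). Compound 4 is estimated at 48000 nM in the this assay, with a likely range from 20000 nM to 100000 nM.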

Compound 4, half-maximal inhibitory concentration: > 50000 nM
Compound 4: no number, only a limit; the forecaster's own chance of this, stated with the estimate: 45%; middle value at least 1.0-fold (0.01 log units) away from the limit.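

The 3-aminophenyl group, with its hydrogen-bond donor, leaves compound 4 at a limit of this assay and not at a number, as compound 3 also stands: the limit of > 50000 nM in this assay, at which 2 of the 4 values shown sit.

The readable steps, an at least 1.0-fold higher number from compound 1 to compound 4 (0.01 log units; that floor lies within the scatter) and an at least 1.0-fold higher number from compound 2 to compound 4 (0.02 log units; that floor lies within the scatter), both have floors within the scatter, so on the numbers shown amino in place of hydrogen does not separate compound 4 from compound 1, nor does 3-aminophenyl in place of 4-methoxyphenyl separate it from compound 2. The step between compound 3 and compound 4 cannot be read, and no readable step among the four compounds, now including one with an amino group on that ring, lies beyond the scatter.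

The compounds shown leave open how far past the limit compound 3 and compound 4 lie, and whether any group on that nitrogen moves the number beyond the scatter at all. A carboxylic acid or a dimethylamino group on the ring, or a longer alkyl chain in place of the aryl group, would be further changes at this position to set against these four.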